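Octyl in Place of Cyclopropyl on the Alkyne

This account rests on a few compounds, and the source may have more. Where it says the series, first, only, none or still open, it means among the compounds named here.

Compound 1 `CC(=O)OCC(CCn1cc(C#CCc2ccccc2)c(=O)n(C(=O)c2ccccc2)c1=O)COC(C)=O` and compound 2 `CC(=O)OCC(CCn1cc(C#CC2CC2)c(=O)n(C(=O)c2ccccc2)c1=O)COC(C)=O` share one core and differ only on a triple-bonded carbon. In a functional assay on SW-620 cells (Homo sapiens) for antiproliferative activity, read by MTT assay, with a stated time of 72 h (a lower number here means a stronger inhibitor, a higher number a weaker inhibitor), compound 1 gives 36400 nM. For compound 2 the assay reports only a limit, > 100000 nM, namely (the limit of > 100000 nM in this assay, at which 1 of the 2 values shown sits). Within the data shown here, the single measured step, an at least 2.7-fold higher number from compound 1 to compound 2 (0.43 log units; beyond the scatter), moved the number upward. Compound 3 `CCCCCCCCC#Cc1cn(CCC(COC(C)=O)COC(C)=O)c(=O)n(C(=O)c2ccccc2)c1=O` carries octyl in place of cyclopropyl on a triple-bonded carbon. Among the measured compounds shown here, no measured step covers a straight chain here, so with compound 2 sitting at the limit the expected step of an at least 1.6-fold lower number from compound 2 to compound 3 (0.22 log units; that floor lies within the scatter) is small and uncertain in direction. Compound 3 is estimated at 60000 nM, within 20000 nM to 200000 nM.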

Compound 3, half-maximal inhibitory concentration: 65800 nM
Estimate against measurement, compound 3: 1.1-fold (0.04 log units) below, and the stated range covers the measured number.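

In this assay, a long open chain on the triple-bonded carbon gives a number that cannot be told apart from that of the benzyl-type group in compound 1 (a 1.8-fold higher number from compound 1 to compound 3 (0.26 log units; within the scatter)). So the octyl chain of compound 3 gives a measured number at this position, which compound 2 did not. The step on the cyclopropyl side gives only a floor within the scatter (an at least 1.5-fold lower number from compound 2 to compound 3 (0.18 log units; that floor lies within the scatter)), and compound 2 stands at a limit of the assay: the limit of > 100000 nM in this assay, at which 1 of the 3 values shown sits.

As far as these compounds go, whether a shorter straight chain such as butyl, or an octyl chain ending in an amine, would shift the number beyond the scatter stays open.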